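The source may hold more compounds than are shown below. What is called first, only, known or untested is meant among the compounds shown, and "the series" means these compounds.

Working notes on the series.

Among the measured compounds shown here, compound 2 `CCOC(=O)C(=O)C(CC)NC(=O)C(CC(C)C)NC(=O)OCc1ccccc1` gives 300000 nM in a functional assay for inhibition, with Rattus norvegicus as the target, at pH 7.35 (on this read-out lower numbers stand for stronger inhibition and higher numbers for weaker inhibition), the highest of the three numbers so far. Compound 1 `CCC(NC(=O)C(CC(C)C)NC(=O)OCc1ccccc1)C(=O)C(=O)OC` gives 280000 nM, and the step of a 1.1-fold higher number from compound 1 to compound 2 (0.03 log units; within the scatter) is a change of methyl in place of hydrogen on a saturated chain carbon bound to an oxygen next to a carbonyl group. Compound 3 `CCOC(=O)C(=O)C(CC)NC(=O)C(CC(C)C)NC(=O)CCc1ccccc1` gives 20000 nM; the step of a 15-fold lower number from compound 2 to compound 3 (1.18 log units; beyond the scatter) is a change of phenethyl in place of benzyloxy on a carbonyl carbon.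

Compound 4 `CCCCC(NC(=O)C(CC(C)C)NC(=O)OCc1ccccc1)C(=O)C(=O)OCC` has not been measured. The change from compound 2 is ethyl in place of hydrogen on a saturated chain carbon, three bonds along the chain from an amide-type nitrogen and a carbonyl carbon. For the measured compounds named here, neither measured step touches this saturated chain carbon: the step from compound 1 to compound 2 sits on the ester oxygen, the step from compound 2 to compound 3 on the carbonyl carbon of the carbamate, so no precedent for a side-chain extension exists in this set. With nothing pointing either way, compound 4 is expected to sit near compound 2, a step of a 1.4-fold lower number from compound 2 to compound 4 (0.13 log units; within the scatter) within the scatter. The estimate for compound 4 is 220000 nM, in the range 60000 nM to 800000 nM.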

Compound 4, half-maximal inhibitory concentration: 150000 nM
Compound 4: the middle estimate sits 1.5-fold (0.17 log units) above what was measured; low and high end bracket the measured number.
By their numbers in this assay, from the lowest: compound 3; then compounds 4, 1 and 2 (each within the scatter of the next).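

Among the compounds shown here, this is the first reading at the saturated chain carbon, three bonds along the chain from an amide-type nitrogen and a carbonyl carbon: ethyl in place of hydrogen gives a 2.0-fold lower number from compound 2 to compound 4 (0.30 log units; within the scatter) in this assay for this change. Taking the side chain from ethyl to butyl therefore shifts the number no further than the scatter, and phenethyl in place of benzyloxy on a carbonyl carbon stays the only step in the series that lies beyond it. No measurement on hand bears on why this position reads as it does.

Open, going by these compounds, is whether a chain longer than butyl, or an amine or a carboxylic acid at the end of this side chain, would give a step beyond the scatter. Also open, on these data alone, is whether ethyl in place of hydrogen at this carbon reads the same with the phenethyl group of compound 3.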